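Replacing the piperazine aryl group in compound 1

The source may hold more compounds than are shown below. What is called first, only, known or untested is meant among the compounds shown, and "the series" means these compounds.

Measured compounds:
compound 1, `Nc1scc(CN2CCN(c3ccc(Cl)c(C(F)(F)F)c3)CC2)c1C(=O)c1ccc(Cl)cc1`: -60%
compound 2, `Nc1scc(CN2CCC(c3ccc(Cl)cc3)CC2)c1C(=O)c1ccc(Cl)cc1`: -61%
compound 3, `Nc1scc(CN2CCN(c3c(F)cccc3F)CC2)c1C(=O)c1cccc(C(F)(F)F)c1`: 4%

Of the compounds shown here, three have been tested in a functional assay on CHO cells with adenosine receptor A1 (Homo sapiens) as the target, read by cAMP accumulation and immunoassay, with a stated time of 6 min, tested at 10 uM; on this read-out higher numbers stand for a weaker effect at the one concentration tested and lower numbers for a stronger effect. Compound 1 gives -60% in this assay, which places it second highest of the three numbers; compound 2 gives -61%, a number within the scatter of compound 1, so the two cannot be told apart. Compound 3 gives 4%, which lies far beyond the scatter from compound 1 and stands for a much weaker effect at the one concentration tested. Compound 3 differs from compound 1 in more than one place, so its gap cannot be tied to a single change.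

Compound 4, `Nc1scc(CN2CCN(c3cccc(F)c3F)CC2)c1C(=O)c1ccc(Cl)cc1`, has not been measured in this assay. It differs from compound 1 in one place: 2,3-difluorophenyl in place of 4-chloro-3-(trifluoromethyl)phenyl on an amine nitrogen in a ring. Going by the values given here, the smaller group with two fluorine atoms on the ring nitrogen is the only change, and the rest of compound 1 is kept. Among the compounds with values here, no single-change step is known here, so any expectation rests on the whole set. Compound 3, also carrying a fluorinated phenyl on the ring nitrogen, gives 4%, which points toward a weaker effect. Compound 4 is therefore expected to give -25%, within -60% to 10%. The step of a number 35 percentage points higher from compound 1 to compound 4 (beyond the scatter) is expected to be a move toward weaker activity, larger than the scatter.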

Compound 4, a percentage reported as activity, at one concentration (the size of the read-out at that concentration, not a potency): -79%
For compound 4 the middle estimate is 54 percentage points above the measured one, outside the stated range (below it).
By their numbers in this assay, from the lowest: compound 4; then compounds 2 and 1 (each within the scatter of the next); then compound 3.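

In this assay, the exchange on the amine nitrogen of the six-membered ring gives a number 19 percentage points lower from compound 1 to compound 4 (beyond the scatter), a modest move toward a stronger effect at the one concentration tested. The position therefore accepts 2,3-difluorophenyl in place of 4-chloro-3-(trifluoromethyl)phenyl without any loss of effect, and the chlorine and the trifluoromethyl group are not needed for the effect seen with the rest of compound 1 kept. Nothing in the data shown accounts for the direction of this step.

Going by these compounds alone, as the single step removes the chlorine and the trifluoromethyl group and brings in two fluorine atoms all at once, it cannot say which of these parts of the change sets the size of the step, and a plain phenyl, a 4-fluorophenyl or a cyclohexyl group on the same ring nitrogen would help to separate them. The read-out also comes from one concentration, so it leaves open whether the step would hold as a difference in potency.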